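Working notes: from compound 2 to compound 4

This account rests on a few compounds, and the source may have more. Where it says the series, first, only, none or still open, it means among the compounds named here.

Measured in an ADME assay on HepG2 cells (Homo sapiens) for cytotoxicity, with a stated time of 72 h; on this read-out lower numbers stand for an effect already at smaller amounts and higher numbers for an effect only at larger amounts of compound:
- compound 1 `Cc1cc(NC(=O)Nc2ccc(C)c(Cl)c2)c2ccccc2n1`: > 25000 nM (a limit)
- compound 2 `CCc1ccc(NC(=O)Nc2cc(C)nc3ccccc23)cc1`: 17000 nM
- compound 3 `Cc1cc(NC(=O)Nc2ccccc2C(C)(C)C)c2ccccc2n1`: > 25000 nM (a limit)

Going by the values given here, compound 2 gives the only number in the set, 17000 nM. For compound 1 and compound 3 the read-out is the limit of > 25000 nM in this assay, at which 2 of the 3 values shown sit. Compound 4 `Cc1cc(NC(=O)Nc2ccc(F)cc2)c2ccccc2n1` differs from compound 2 in one place: fluoro in place of ethyl on an aromatic carbon. Among the compounds with values here, no measured step exists, so the expectation starts from compound 2 at 17000 nM. A small upward step in this assay is expected, possibly none beyond the scatter. The estimated step is a 1.2-fold higher number from compound 2 to compound 4 (0.09 log units; within the scatter). The expected value for compound 4 is 21000 nM, with an estimated range of 11000 nM to 40000 nM.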

Compound 4, half-maximal effective concentration: > 25000 nM
Compound 4: a limit, no number; the forecaster's own chance of this, stated with the estimate: 50%; middle value at least 1.1-fold (0.07 log units) away from the limit.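

Going by these compounds alone, on the aromatic carbon para to a large group, fluoro in place of ethyl gives the first readable step: an at least 1.4-fold higher number from compound 2 to compound 4 (0.16 log units; that floor lies within the scatter). As far as these compounds go, this is only a floor, since compound 4 gives a limit and no number in this assay, so the true size of the step stays unknown. Among the compounds shown, ethyl at this place is the only group that gives a number, and fluoro returns the read-out to the limit: the limit of > 25000 nM in this assay, at which 3 of the 4 values shown sit.

From the compounds shown here alone, how far compound 4 lies past that limit remains open. So does whether a propyl chain or an amine at this place would give a number.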